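A few compounds are considered here, and "the series" means these few. Any claim that something is new, unique, unknown or untested is made for them only; others in the source may bear on it.

Of the compounds shown here, three sharing one core have been measured in an ADME assay, in phosphate buffer, at 28 degrees C, at pH 7.0; a higher number here means that the compound lasts longer, a lower number that the compound disappears faster. Compound 1 `CC(C)(C)C1=C(C(=O)O)N2C(=O)[C@H](CO)[C@H]2O1` gives 5 h. Compound 2 `C[C@@H](O)[C@H]1C(=O)N2C(C(=O)O)=C(C(C)(C)C)O[C@H]12` gives 8.1 h, and compound 3 `CC(C)(C)C1=C(C(=O)O)N2C(=O)[C@H]([C@H](O)c3ccncc3)[C@H]2O1` gives 6.4 h. On these numbers compound 2 has the highest value of the three, yet the step of a 1.6-fold higher number from compound 1 to compound 2 (0.21 log units; within the scatter) and the step of a 1.3-fold lower number from compound 2 to compound 3 (0.10 log units; within the scatter) are both within the scatter, as is a 1.3-fold higher number from compound 1 to compound 3 (0.11 log units; within the scatter), so the three results cannot be told apart with confidence.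

Compound 4 `C[C@@H](O)[C@H]1C(=O)N2C(C(=O)O)=C(C(C)(C)C)O[C@@H]12` is next. Compared with compound 2, (the two compounds have the same atoms and bonds and differ only in configuration as drawn: 1 of 3 stereo elements differ; a stereocentre at a saturated ring carbon is drawn R in compound 2 and S in compound 4). For the measured compounds named here, none of the measured steps changes a stereocentre; each of them exchanges a group on the saturated chain carbon bound to an oxygen on a saturated carbon and a saturated ring carbon, and each stays within the scatter. Going by the values given here, no measured step therefore bears directly on the change from compound 2 to compound 4, and the expectation rests only on the narrow spread of the three measured values.

For compound 4 a step of a 1.2-fold lower number from compound 2 to compound 4 (0.10 log units; within the scatter) is expected, with wide uncertainty because the value of compound 2 at 8.1 h is the only anchor. Compound 4 is estimated at 6.5 h, within 2.5 h to 16 h.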

Compound 4, half-life: 6.4 h
Estimate against measurement, compound 4: 1.0-fold (0.01 log units) above; measured number inside the range.
By their numbers in this assay, from the lowest: compounds 1, 3, 4 and 2 (each within the scatter of the next).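

For the compounds shown here, the earlier steps all exchanged a group on the saturated chain carbon, whereas this is the first to change a stereocentre, at a saturated ring carbon drawn R in compound 2 and S in compound 4. In this assay, the step is a 1.3-fold lower number from compound 2 to compound 4 (0.10 log units; within the scatter), so changing this one centre gives no readable difference in this pair. The comparison tests that centre alone because of one fact: the fact that compounds 2 and 4 differ only in the configuration as drawn.

The compounds shown leave open whether the same change of configuration would also give no readable difference with pyridin-4-yl on the chain carbon, or with an amine in place of the oxygen on that carbon. They also leave open what a change at either of the other two stereo elements would do.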